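The compounds below may be only part of what the source reports. "The series", "measured", "known", "first", "only" and "open" are said of these compounds alone.

Series notes. Compound 1 `O=C(Nc1ccc(F)cc1)c1cc(Cl)ccc1O` gives 17000 nM in an ADME assay on cells (Macrophage, Mus musculus) for cytotoxicity, read by resazurin assay, with a stated time of 3 days; on this read-out lower numbers stand for stronger inhibition and higher numbers for weaker inhibition. Compound 2 `O=C(Nc1ccc(F)cc1F)c1cc(Cl)ccc1O` gives 8500 nM in this assay. Compound 3 `O=C(Nc1cc(C(F)(F)F)ccc1F)c1cc(F)ccc1O` gives 5100 nM in this assay; the gap between compound 3 and compound 2 is within the scatter, that between compound 3 and compound 1 is beyond it. The step of a 2.0-fold higher number from compound 2 to compound 1 (0.30 log units; within the scatter) goes with the change (hydrogen in place of fluoro on an aromatic carbon).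

Compound 4 `O=C(Nc1cccc(C(F)(F)F)c1)c1cc(F)ccc1O` is not yet measured. It is obtained from compound 3 by hydrogen in place of fluoro on an aromatic carbon. This is the same kind of change as that from compound 2 to compound 1, not the same: the surroundings differ, one place being meta to a fluoro group, the other para to a trifluoromethyl group. The difference between the core of compound 3 and that of compound 2 is not broken down here.

Among the measured compounds shown here, only one measured instance of this change exists, and it stayed within the scatter, so a similar, small step is expected for compound 4, because a 2.0-fold higher number from compound 2 to compound 1 (0.30 log units; within the scatter) was small. The expected step is a 1.6-fold higher number from compound 3 to compound 4 (0.20 log units; within the scatter). Compound 4 is estimated at 8000 nM, with a range from 4000 nM to 16000 nM.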

Compound 4, half-maximal inhibitory concentration: 6100 nM
The estimate for compound 4 lay 1.3-fold (0.12 log units) above the measured number, and the stated range covers the measured number.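

Replacing the fluoro group with hydrogen gives a 1.2-fold higher number from compound 3 to compound 4 (0.08 log units; within the scatter), and this step can now be set beside the earlier instance of the same change: the same change on two cores in this assay, a 2.0-fold higher number (0.30 log units; within the scatter) from compound 2 to compound 1 and a 1.2-fold higher number (0.08 log units; within the scatter) from compound 3 to compound 4, 1.7-fold (0.22 log units) apart, within the scatter of two such steps. In this assay, the change therefore stays small on both the core of compound 2 and the core of compound 3, and the two steps cannot be told apart. Both steps lie within the scatter, so neither is established as a real shift on its own, and two cores are too few to fix a size for the step or to show that it would stay small on a further core.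

Still open, from the compounds shown here alone, is how the number responds when the fluoro group gives way to something other than hydrogen, such as an amine or a methoxy group. Also open, going by these compounds, is whether the change stays as small on a core carrying a carboxylic acid in place of the hydroxy group.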